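Adding a second methoxy group to compound 3

A few compounds are considered here, and "the series" means these few. Any claim that something is new, unique, unknown or untested is made for them only; others in the source may bear on it.

Of the compounds shown here, three built on a shared core have been tested in an assay on CHO cells for displacement of a labelled ligand from Alpha-2C adrenergic receptor (Homo sapiens); a higher number here means a weaker inhibitor, a lower number a stronger inhibitor. Compound 1 `Brc1c(Nc2ncc[nH]2)ccc2nccnc12` gives only a limit, > 10000 nM, and not a number (the limit of > 10000 nM in this assay, at which 1 of the 3 values shown sits). Compound 2 `Clc1cccc(Cl)c1Nc1ncc[nH]1` gives 1100 nM. Compound 3 `COc1ccc(Nc2ncc[nH]2)c(C)c1` gives 512 nM, the lowest of the two numbers, and its gap to compound 2 lies beyond the usual scatter of repeat measurements. Compound 4 `COc1ccc(Nc2ncc[nH]2)c(C)c1OC` has not yet been measured. It differs from compound 3 by methoxy in place of hydrogen on an aromatic carbon. No measured pair among these compounds shows what such an addition does, so there is no step to lean on. The expectation is therefore a modest change at most, leaning towards a slightly higher number, with a wide range on either side. Compound 4 is expected to give about 700 nM in this assay, within a range from 200 nM to 2500 nM, a step of a 1.4-fold higher number from compound 3 to compound 4 (0.14 log units; within the scatter) that is estimated to sit close to the scatter.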

Compound 4, inhibition constant: 1500 nM
The estimate for compound 4 lay 2.1-fold (0.33 log units) below the measured number, within the range that was stated.
By their numbers in this assay, from the lowest: compound 3; then compounds 2 and 4 (each within the scatter of the next). At a limit, above all of these: compound 1.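

Among the compounds shown here, this pair gives the first direct reading of methoxy in place of hydrogen on an aromatic carbon: in this assay, the change produces a clear but limited loss of strength (a 2.9-fold higher number from compound 3 to compound 4 (0.47 log units; beyond the scatter)). The step lies beyond the usual scatter, so at this place, ortho to a methoxy group and ortho to a methyl group, the added methoxy makes the inhibitor weaker instead of leaving it unchanged. A single pair shows this for one place on one compound, so it sets no general rule for methoxy on this core.

Going by these compounds, whether a hydroxyl group, an amine or a longer chain at the same place would give a similar step remains open, as does the effect of methoxy elsewhere on the six-membered ring. Nothing shown here bears on why the number rises with this change.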